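Moving the methyl on the phenoxy ring of an oxazolidinone imide

The compounds below may be only part of what the source reports. "The series", "measured", "known", "first", "only" and "open" are said of these compounds alone.

Measured compounds:
- compound 1, `O=C1OCCN1C(=O)c1ccc(Oc2ccccc2)cc1`: 680 nM
- compound 2, `Cc1cccc(Oc2ccc(C(=O)N3CCOC3=O)cc2)c1`: 5210 nM

In an assay on HEK293 cells for inhibition of N-acylethanolamine-hydrolyzing acid amidase (Rattus norvegicus), read by LC-MS, with a stated time of 30 min (a lower number here means a stronger inhibitor, a higher number a weaker inhibitor), compound 2 stands highest of the two numbers; its nearest neighbour is compound 1, and the step of a 7.7-fold higher number from compound 1 to compound 2 (0.88 log units; beyond the scatter) puts a methyl on an aromatic carbon of the phenoxy ring. Compound 3, `Cc1ccc(Oc2ccc(C(=O)N3CCOC3=O)cc2)cc1`, has not been measured. It differs from compound 2 by 4-methylphenyl in place of 3-methylphenyl on an oxygen on an aromatic ring. Going by the values given here, no measured step bears directly on this change, since the only step available, a 7.7-fold higher number from compound 1 to compound 2 (0.88 log units; beyond the scatter), compares methyl with hydrogen rather than two placements of the same methyl. The expectation for compound 3 therefore rests on compound 2 alone, with the step to compound 1 marking how far a single methyl has moved the number. Compound 3 is estimated at 3000 nM, with a range of 800 nM to 12000 nM; the expected step is a 1.7-fold lower number from compound 2 to compound 3 (0.24 log units; within the scatter), a shift not confidently beyond the scatter.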

Compound 3, half-maximal inhibitory concentration: 6400 nM
Estimate against measurement, compound 3: 2.1-fold (0.33 log units) below; measured number inside the range.
By their numbers in this assay, from the lowest: compound 1; then compounds 2 and 3 (each within the scatter of the next).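

In this assay, shifting the methyl by putting 4-methylphenyl in place of 3-methylphenyl on an oxygen on an aromatic ring gives a 1.2-fold higher number from compound 2 to compound 3 (0.09 log units; within the scatter), so these two placements cannot be told apart. Adding the methyl in the 4-methylphenyl placement gives a 9.4-fold higher number from compound 1 to compound 3 (0.97 log units; beyond the scatter), so both methyl compounds stand apart from compound 1, and in these three compounds the presence of the methyl counts for more than which of these two placements it takes. No evidence is available on what lies behind this result.

Still open, as far as these compounds go, is whether a chlorine, a methoxy group or a carboxylic acid in either placement would behave as methyl does. From the compounds shown here alone, it is also open whether an ethyl group or a longer chain there would bring the number closer to that of compound 1 or move it further away.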